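The compounds below may be only part of what the source reports. "The series", "measured", "known", "first", "only" and "open" are said of these compounds alone.

Compound 3, `COC(=O)c1ccc(-c2nnn(CC(=O)C(C)Oc3ccc(Oc4ccc(Cl)cc4)cc3)n2)cc1`, is the point of departure. In an ADME assay on S9 fraction from liver (Rattus norvegicus) for metabolic stability, read by LC-MS, using NADPH, with a stated time of 30 min (a higher number here means that more of the compound is left, a lower number that less of the compound is left), compound 3 gives < 5%, which is a limit of the assay rather than a number, (the limit of < 5% in this assay, at which 1 of the 3 values shown sits). Two other compounds give fuller bearings. Within the data shown here, compound 2, `CCCCCCCCc1ccc(OC(C)C(=O)Cn2nnc(-c3ccc(C(=O)OC)cc3)n2)cc1`, carries an octyl chain where compound 3 carries a 4-chlorophenoxy group, and in this assay compound 2 gives 62%; the step of a number at least 57 percentage points lower from compound 2 to compound 3 (beyond the scatter) is the only measured step in this set. Compound 1, `CC(Oc1ccc(Oc2ccc(C(F)(F)F)cc2)cc1)C(=O)Cn1nnc(-c2ccc(Cl)cc2)n1`, already carries the 4-(trifluoromethyl)phenoxy group, though it carries chloro where compound 3 carries a methyl ester, and in this assay compound 1 gives 9%.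

Compound 4, `COC(=O)c1ccc(-c2nnn(CC(=O)C(C)Oc3ccc(Oc4ccc(C(F)(F)F)cc4)cc3)n2)cc1`, differs from compound 3 by trifluoromethyl in place of chloro on an aromatic carbon. Among the measured compounds shown here, no measured step covers this exact swap: the step from compound 2 to compound 3 concerns a different change, and compound 1 and compound 3 differ in two places, so their values can only be set side by side. Compound 3 sits at the limit. Given that compound 1, the one measured compound bearing the trifluoromethyl group, gives 9%, compound 4 is expected to stay low. The expected step is a number at least 1 percentage points higher from compound 3 to compound 4 (that floor lies within the scatter), nothing beyond the scatter. The estimate for compound 4 is 6%, between 2% and 14%, with a fair chance that the assay again reports only its limit.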

Compound 4, percent of the compound remaining: 15%
Compound 4: the middle estimate sits 9 percentage points below what was measured; the whole stated range lies below it.
By their numbers in this assay, from the lowest: compounds 1 and 4 (each within the scatter of the next); then compound 2. At a limit, below all of these: compound 3.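

Compound 3 stands at a limit of the assay, not at a number: the limit of < 5% in this assay, at which 1 of the 4 values shown sits. In this assay, trifluoromethyl in place of chloro, para to a large group, can therefore be read only as a number at least 10 percentage points higher from compound 3 to compound 4 (that floor lies within the scatter), so this swap between two aryloxy substituents shows no change that can be told apart from the usual spread of repeats. The larger contrast is with the octyl chain, at a number 47 percentage points lower from compound 2 to compound 4 (beyond the scatter), which matches the drop already seen for 4-chlorophenoxy and now gives two aryloxy groups on the same side of compound 2, while methoxycarbonyl in place of chloro elsewhere on the molecule comes to a number 6 percentage points higher from compound 1 to compound 4 (within the scatter), a step that also stays inside the scatter.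

Going by these compounds, it stays open where a shorter chain such as butyl or hexyl would fall between compound 2 and compound 4 at this position, and whether a plain methoxy group would behave more like the octyl chain or like the aryloxy groups. On these data alone, the effect of a carboxylic acid in place of the methyl ester, with the 4-(trifluoromethyl)phenoxy group kept, also remains open.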